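Catechol ether amides: swapping the anilide ring for a thiazole

A few compounds are considered here, and "the series" means these few. Any claim that something is new, unique, unknown or untested is made for them only; others in the source may bear on it.

Measured so far:
- compound 1, `COc1ccc(C(=O)Nc2c(F)cccc2Cl)cc1OC1CCCC1`: 240 nM
- compound 2, `O=C(Nc1c(F)cccc1F)c1cccc(OC2CCCC2)c1`: 15000 nM
- compound 3, `COc1ccc(/C(S)=N/c2ccccc2Cl)cc1OC1CCCC1`: 200 nM

All three numbers come from an assay on isolated protein for inhibition of phosphodiesterase 4A (Sus scrofa); a higher number here means a weaker inhibitor, a lower number a stronger inhibitor. Compound 1 gives 240 nM, the second highest of the three. Its nearest neighbour is compound 3 with 200 nM, a gap that lies within the scatter, so no order between the two can be read. Compound 2, with 15000 nM, stands far weaker, well beyond the scatter; it lacks the methoxy group of the shared core and carries a different anilide ring, so the two values alone do not say which change matters.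

Compound 4, `COc1ccc(C(=O)Nc2c(C)nsc2C#N)cc1OC1CCCC1`, is not yet measured. It differs from compound 1 in one place: 5-cyano-3-methyl-1,2-thiazol-4-yl in place of 2-chloro-6-fluorophenyl on an amide-type nitrogen. For the measured compounds named here, no step between measured compounds covers a swap of this kind, so the expectation rests on compound 1 alone. The step from compound 1 to compound 4 is expected to be modest, a 1.7-fold higher number from compound 1 to compound 4 (0.22 log units; within the scatter), most likely toward a somewhat higher number, within or just beyond the scatter.

Compound 4 is expected to give 400 nM in this assay, with a range from 100 nM to 2000 nM.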

Compound 4, half-maximal inhibitory concentration: 200 nM
Compound 4: middle estimate off by 2.0-fold (0.30 log units), on the high side; the measured number falls inside the stated range.
By their numbers in this assay, from the lowest: compounds 3, 4 and 1 (each within the scatter of the next); then compound 2.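

The swap of 2-chloro-6-fluorophenyl for 5-cyano-3-methyl-1,2-thiazol-4-yl on the amide-type nitrogen gives, in this assay, a 1.2-fold lower number from compound 1 to compound 4 (0.08 log units; within the scatter), so the two compounds cannot be told apart. This place on the amide therefore accepts a five-membered aromatic ring with 2 hetero atoms and a nitrile in place of a six-membered carbon-only ring bearing chlorine and fluorine, with no readable difference, even as the hydrogen-bond acceptors counted on the group go from 0 to 3. Nothing available bears on why the value holds across this swap.

The compounds shown do not separate the nitrile from the methyl on the new ring, and a carboxylic acid or primary amide in place of the nitrile would test that part of the group. Also open, on these data alone, is whether the swap holds on a core without the methoxy group, as in compound 2.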